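The source may report more compounds than this note shows. Statements on the series, on what has been measured and on what is new or still open speak of the compounds shown alone.

Working notes on the series. The shared core carries a urea arm whose terminus varies. Compound 1 `CCOC(=O)CNC(=O)NCc1ccc(C(=O)N2CCCCc3ccccc32)cc1C` gives 140 nM in a functional assay on HEK293 cells for agonist activity at Vasopressin V2 receptor (Homo sapiens), read by a luciferase reporter and cAMP accumulation; a lower number here means that less compound is needed, a higher number that more compound is needed for the effect. Compound 2 `Cc1cc(C(=O)N2CCCCc3ccccc32)ccc1CNC(=O)NCC(=O)OC(C)C` gives 140 nM in this assay, and the step of no change at the digits printed from compound 1 to compound 2 (within the scatter) lies within the scatter. Compound 3 `Cc1cc(C(=O)N2CCCCc3ccccc32)ccc1CNC(=O)NCC(=O)N1CCCCC1` gives 150 nM in this assay; the steps of a 1.1-fold higher number from compound 1 to compound 3 (0.03 log units; within the scatter) and a 1.1-fold higher number from compound 2 to compound 3 (0.03 log units; within the scatter) are likewise within the scatter, so compound 3 stands indistinguishable from compounds 1 and 2 on these numbers.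

Compound 4 `Cc1cc(C(=O)N2CCCCc3ccccc32)ccc1CNC(=O)N1C[C@H](O)C[C@H]1C(=O)N(C)C` is not yet measured. It differs from compound 3 by 2-(dimethylcarbamoyl)-4-hydroxypyrrolidin-1-yl in place of (((piperidin-1-yl)carbonyl)methyl)amino on a carbonyl carbon. The measured steps bear only indirectly on this: each of them exchanged what sits on the terminal carbonyl carbon and moved the number by nothing beyond the scatter, whereas this change also folds the urea nitrogen into a ring and adds a hydroxyl. Among the compounds with values here, no measured step covers that part, so the expectation is taken from the flat behaviour of compounds 1 to 3 with a wide range. The step of no change at the digits printed from compound 3 to compound 4 (within the scatter) is therefore expected to be small in this assay, with no direction favoured. Compound 4 is estimated at 150 nM, with a range of 40 nM to 600 nM, in this assay.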

Compound 4, half-maximal effective concentration: 2.3 nM
For compound 4 the middle estimate is 65-fold (1.81 log units) above the measured one; measured number outside the range, below it.
By their numbers in this assay, from the lowest: compound 4; then compounds 1, 2 and 3 (each within the scatter of the next).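

In this assay, the step of a 65-fold lower number from compound 3 to compound 4 (1.81 log units; beyond the scatter) shows that the group on this carbonyl carbon is far from indifferent, and the same entering group gives a 61-fold lower number from compound 2 to compound 4 (1.78 log units; beyond the scatter) and a 61-fold lower number from compound 1 to compound 4 (1.78 log units; beyond the scatter) against the two ester arms. The exchanges among compounds 1, 2 and 3 altered only the end of the open arm and stayed within the scatter, so the sensitivity appears here only with 2-(dimethylcarbamoyl)-4-hydroxypyrrolidin-1-yl replacing that whole arm. Nothing available explains this gain.

The compounds shown do not separate the contributions of the five-membered ring, the hydroxyl, the dimethylcarbamoyl group and the two defined stereocentres. Also open, going by these compounds, is how the number responds to a plain pyrrolidin-1-yl, to the opposite stereoisomers, or to a carboxylic acid or a primary amide replacing the dimethylcarbamoyl group.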